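Dimethylamino in place of 2-aminoethyl: reading past limits

The compounds below may be only part of what the source reports. "The series", "measured", "known", "first", "only" and "open" are said of these compounds alone.

Values in a functional assay on the whole organism for positive allosteric modulation, with Mus musculus as the target (a higher number here means that more compound is needed for the effect, a lower number that less compound is needed), each one a limit:
Compound 1 (`Cc1cc(-c2ccccc2)nnc1NCCCN`) gives > 30 mg/kg
Compound 2 (`Cc1cc(-c2ccccc2)nnc1NCCCCN`) gives > 30 mg/kg
Compound 3 (`CNCCNc1nnc(-c2ccccc2)cc1C`) gives >= 30 mg/kg

Compound 2 stands at > 30 mg/kg, which is a limit and not a number. Compound 4 (`Cc1cc(-c2ccccc2)nnc1NCCN(C)C`) has the same atoms, joined differently, with dimethylamino in place of 2-aminoethyl (dimethylamino in place of 2-aminoethyl on a saturated chain carbon, two bonds along the chain from a nitrogen on an aromatic ring). The closest measured change puts methylamino at that same place, and it is a step that the two limits leave unreadable from compound 2 to compound 3 here. The other two measured changes are a step that the two limits leave unreadable from compound 1 to compound 2 and a step that the two limits leave unreadable from compound 1 to compound 3 here. None of these gives a size to carry over, so no step beyond the usual scatter can be expected in this assay. The expected change is a number no higher from compound 2 to compound 4 (the limit leaves the size open) here. For compound 4 the estimated value is 30 mg/kg, within an expected range of 10 mg/kg to 80 mg/kg here.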

Compound 4, dose for half-maximal effect: > 30 mg/kg
Compound 4: only a limit was reported; the forecaster's own chance of this, stated with the estimate: 65%; the middle value sits exactly at the limit.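

In this assay, within the data shown here, compound 4 gives > 30 mg/kg, a limit and not a number, so no step between compound 4 and compound 1, compound 2 or compound 3 can be read. The compounds shown leave open whether dimethylamino and 2-aminoethyl differ at all in the dose needed.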